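The compounds below may be only part of what the source reports. "The series", "measured", "known", "first", "only" and "open" are said of these compounds alone.

Working notes on the sulfamate series in an assay on HEK293 cells for inhibition of Steryl-sulfatase (Homo sapiens), tested at 0.1 uM; on this read-out higher numbers stand for a stronger effect at the one concentration tested and lower numbers for a weaker effect.

Within the data shown here, compound 3, `NS(=O)(=O)Oc1ccc2c(c1)CN(C(=O)c1ccc(N(Cc3ccccc3)Cc3ccco3)cc1)CC2`, gives 90.8% and stands highest of the three numbers so far. Compound 2, `CCCN(Cc1ccccc1)c1ccc(C(=O)N2CCc3ccc(OS(N)(=O)=O)cc3C2)cc1`, gives 64.8%, and compound 1, `CN(C)CCN(CCN(C)C)c1ccc(C(=O)N2CCc3ccc(OS(N)(=O)=O)cc3C2)cc1`, gives 3.8%; the gap from compound 3 to each of them lies beyond the scatter.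

Two measured steps frame the series: a number 61 percentage points higher from compound 1 to compound 2 (beyond the scatter), and a number 26 percentage points higher from compound 2 to compound 3 (beyond the scatter). The first shows that carrying two dimethylaminoethyl groups on the aniline nitrogen goes with a very weak number; the second shows that the furanylmethyl group on that nitrogen adds a modest gain over the ethyl-terminated chain.

Compound 4, `CN(C)CCN(Cc1ccccc1)c1ccc(C(=O)N2CCc3ccc(OS(N)(=O)=O)cc3C2)cc1`, is compound 3 with one change: (dimethylamino)methyl in place of furan-2-yl on a saturated chain carbon bound to a nitrogen on an aromatic ring. The benzyl group stays, so the step reversing compound 2 to compound 3 is the closer guide, while the weak number of compound 1 warns that a dimethylaminoethyl chain on this nitrogen may cost more than the furanyl group gave. A drop beyond the scatter is therefore expected, of the order of a number 48.8 percentage points lower from compound 3 to compound 4 (beyond the scatter). Compound 4 is thus estimated at 42%, with a range of 15% to 70%.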

Compound 4, a percentage reported as inhibition, at one concentration (the size of the read-out at that concentration, not a potency): 13.9%
Compound 4: the middle estimate sits 28.1 percentage points above what was measured; measured number below the stated range.
By their numbers in this assay, from the lowest: compound 1; then compound 4; then compound 2; then compound 3.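

In this assay, one 2-(dimethylamino)ethyl group on the nitrogen, with the benzyl group kept, is enough to bring the number low: the exchange for (furan-2-yl)methyl gives a number 76.9 percentage points lower from compound 3 to compound 4 (beyond the scatter), and the terminal dimethylamino in place of methyl in the propyl chain gives a number 50.9 percentage points lower from compound 2 to compound 4 (beyond the scatter), so the loss appears against both a ring-bearing group and a plain alkyl chain. Phenyl in place of (dimethylamino)methyl gives only a number 10.1 percentage points higher from compound 1 to compound 4 (beyond the scatter), so with one 2-(dimethylamino)ethyl group present, exchanging the other for benzyl recovers little of the ground that separates these compounds from compound 2 and compound 3. Nothing at hand bears on why the dimethylamino-ended chain goes with these low numbers.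

The compounds shown leave open whether the dimethylamino group itself or any terminal amine carries this loss, which a 2-(morpholin-4-yl)ethyl or a 2-aminoethyl group on the same nitrogen would help to separate. Among these compounds, they also leave open whether a 2-methoxyethyl group, with oxygen at that chain place, stays near the propyl number, and whether a longer chain ending in dimethylamino behaves like the one in compound 4.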